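A few compounds are considered here, and "the series" means these few. Any claim that something is new, unique, unknown or untested is made for them only; others in the source may bear on it.

Compound 1 `CCOC(=O)C1=C(N/C=N/c2ncc(-c3ccccc3)s2)Nc2[nH]nc(C)c2C1c1ccc(N(C)C)cc1`: 15400 nM
Compound 2 `CCOC(=O)C1=C(N/N=C(\c2ccc([N+](=O)[O-])cc2)N2CCN(c3ccc(F)cc3)CC2)Nc2[nH]nc(C)c2C1c1ccc(N(C)C)cc1`: 87000 nM
Compound 3 `CCOC(=O)C1=C(N/N=C(\C#N)C(N)=O)Nc2[nH]nc(C)c2C1c1ccc(N(C)C)cc1`: 47300 nM

All three compounds share the same core and were tested in a functional assay on HeLa cells (Homo sapiens) for inhibition, read by MTT assay, with a stated time of 48 h; on this read-out higher numbers stand for weaker inhibition and lower numbers for stronger inhibition. Compound 3 stands second highest of the three numbers. Its value lies within the scatter of that of compound 2, so the two cannot be told apart, whereas compound 1 gives a number that is beyond the scatter below it, meaning compound 1 is the stronger inhibitor of that pair.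

Compound 4 `CCOC(=O)C1=C(N/N=C(/C(=O)Br)c2ccc(Br)cc2)Nc2[nH]nc(C)c2C1c1ccc(N(C)C)cc1` has not yet been measured in this assay. It differs from compound 3 in a single place: a group of 12 heavy atoms (8 carbon, 1 nitrogen, 1 oxygen, 2 bromine; one six-membered aromatic ring of carbon only) in place of a group of 7 heavy atoms (3 carbon, 3 nitrogen, 1 oxygen; no ring), on an amine nitrogen. Within the data shown here, no pair of measured compounds differs in only one place, so nothing in the measured set shows directly how a change of this kind shifts the number. Where compound 3 has no aromatic ring in this group, compound 1 does carry one and gives 15400 nM, but the two differ in several places at once, so this is only a loose hint.

The step from compound 3 to compound 4 is therefore expected to be modest, leaning towards stronger inhibition, at a 1.6-fold lower number from compound 3 to compound 4 (0.20 log units; within the scatter). Compound 4 is estimated at 30000 nM, with a range from 8000 nM to 120000 nM.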

Compound 4, half-maximal inhibitory concentration: 68500 nM
Compound 4: middle estimate off by 2.3-fold (0.36 log units), on the low side, within the range that was stated.
By their numbers in this assay, from the lowest: compound 1; then compounds 3, 4 and 2 (each within the scatter of the next).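

In this assay, exchanging the group on the amine nitrogen gives a 1.4-fold higher number from compound 3 to compound 4 (0.16 log units; within the scatter), so the two compounds cannot be told apart. Among these compounds, this is the first direct comparison at this position, and it shows that a group of 12 heavy atoms, with one six-membered aromatic ring of carbon only and 2 bromine, can take the place of a group of 7 heavy atoms with no ring and 1 triple bond without a readable shift in the number. No measurement shown here explains this result.

The exchange alters the ring, the bromine atoms, the triple bond and the hydrogen-bond donor count all at once, so the compounds shown leave open whether any one of these features matters on its own. They also leave open how the number would respond if this position carried a small group such as methyl, or an amine or a carboxylic acid.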